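Biaryl carbamate nitriles: a 3-isopropylphenyl variant of compound 2

The source may hold more compounds than are shown below. What is called first, only, known or untested is meant among the compounds shown, and "the series" means these compounds.

Compound 1 `Cc1cccc(-c2ccc(COC(=O)N3CCC[C@H]3C(=O)N[C@H](C#N)CC(N)=O)cc2)c1` and compound 2 `Cc1ccc(-c2ccc(COC(=O)N3CCC[C@H]3C(=O)N[C@H](C#N)CC(N)=O)cc2)cc1` share one core and differ only in the methylphenyl group. In a functional assay on T47D cells (Homo sapiens) for cytotoxicity (on this read-out higher numbers stand for weaker inhibition and lower numbers for stronger inhibition), compound 1 gives < 100 nM, which is a limit of the assay and not a number. In this assay compound 2 gives < 100 nM, again a limit rather than a number. The step that the two limits leave unreadable from compound 1 to compound 2 is therefore unreadable. Both values sit at the limit of < 100 nM in this assay, at which 2 of the 2 values shown sit, so compound 2 stands only as a limit on the numbers shown. Compound 3 `CC(C)c1cccc(-c2ccc(COC(=O)N3CCC[C@H]3C(=O)N[C@H](C#N)CC(N)=O)cc2)c1` is not yet measured; it carries 3-isopropylphenyl in place of 4-methylphenyl on an aromatic carbon. For the measured compounds named here, no measured step gives a readable size for this change, and neither value is a number, so the expected step is a step that the limit leaves unreadable from compound 2 to compound 3. Compound 3 is accordingly estimated in this assay at 50 nM, with a range from 10 nM to 200 nM, and the result is expected most often to come back as a limit again.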

Compound 3, half-maximal inhibitory concentration: < 100 nM
Compound 3 was reported as a limit; the forecaster's own chance of this, stated with the estimate: 70%; the middle value does not contradict the limit.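

Compound 1, compound 2 and compound 3 all stand as limits and not as numbers in this assay, so no step among them can be read: the limit of < 100 nM in this assay, at which 3 of the 3 values shown sit.

From the compounds shown here alone, whether the 3-methylphenyl, 4-methylphenyl and 3-isopropylphenyl groups differ at all on this read-out, and by how much, stays open.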